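From compound 2 to compound 4: changing the amide substituent

The source may report more compounds than this note shows. Statements on the series, on what has been measured and on what is new or still open speak of the compounds shown alone.

Working notes on a small series read in a functional assay on DU-145 cells (Homo sapiens) for antiproliferative activity, read by sulforhodamine B assay, with a stated time of 3 days; on this read-out higher numbers stand for weaker inhibition of growth and lower numbers for stronger inhibition of growth. Compound 1 `COc1ccc(N2CCN(C)CC2)cc1Nc1ncc(F)c(Nc2ccc(F)cc2)n1` gives 910 nM. Compound 3 `O=C(Nc1cccc(Nc2ncc(F)c(Nc3ccc(F)cc3)n2)c1)c1cnccn1`, which carries an amide, gives 26400 nM. Compound 2 `O=C(Nc1ccc(C(F)(F)F)cc1)c1cccc(Nc2ncc(F)c(Nc3ccc(F)cc3)n2)c1`, also an amide, gives only a limit of the assay, > 10000 nM.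

Compound 4 `COc1cc(NC(=O)c2cccc(Nc3ncc(F)c(Nc4ccc(F)cc4)n3)c2)cc(OC)c1` has not been measured yet. It carries 3,5-dimethoxyphenyl in place of the 4-(trifluoromethyl)phenyl of compound 2, on an amide-type nitrogen: 3,5-dimethoxyphenyl in place of 4-(trifluoromethyl)phenyl on an amide-type nitrogen.

Among the compounds with values here, no measured pair in this set differs in one place, so the size of this change cannot be read from a measured step. The expectation rests on the values alone: compound 3 at 26400 nM points to weak inhibition of growth for an amide of this kind, while compound 1 at 910 nM has no such amide. A modest shift toward stronger inhibition of growth is expected in this assay, and the estimated change is an at least 1.6-fold lower number from compound 2 to compound 4 (0.22 log units; that floor lies within the scatter), set against a limit and not against a number. A reading at the limit would not be a surprise. For compound 4 the estimate is 6000 nM, with an expected range of 1200 nM to 30000 nM.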

Compound 4, concentration for 50% growth inhibition: 13700 nM
The estimate for compound 4 lay 2.3-fold (0.36 log units) below the measured number, within the range that was stated.
By their numbers in this assay, from the lowest: compound 1; then compounds 4 and 3 (each within the scatter of the next).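

No step can be read from compound 2 to compound 4, because compound 2 stands only at a limit and not at a number: the limit of > 10000 nM in this assay, at which 1 of the 4 values shown sits.

The compounds shown leave open whether 3,5-dimethoxyphenyl in place of 4-(trifluoromethyl)phenyl on an amide-type nitrogen changes inhibition of growth at all, and in which direction.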